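This account rests on a few compounds, and the source may have more. Where it says the series, first, only, none or still open, it means among the compounds named here.

Series notes. In an ADME assay on microsomes from liver (Rattus norvegicus) for metabolic stability, using NADPH, with a stated time of 10 min (on this read-out higher numbers stand for a more stable compound and lower numbers for a less stable compound), compound 1 `CCCCc1nc(=O)c(S(=O)(=O)c2ccc(-n3cc(Cl)ccc3=O)cc2)c(O)n1-c1c(OC)cccc1OC` gives 74%. Compound 2 `CCCCc1[nH]c(=O)c(S(=O)(=O)c2ccc(-c3ccncc3C)cc2)c(O)c1-c1c(OC)cccc1OC` gives 57% in this assay, the lower of the two numbers, and the gap to compound 1 lies beyond the scatter. Compound 3 `CCCCc1[nH]c(=O)c(S(=O)(=O)c2ccc(-n3cc(Cl)ccc3=O)cc2)c(O)c1-c1c(OC)cccc1OC` is not yet measured. It differs from compound 2 by a group of 8 heavy atoms (5 carbon, 1 nitrogen, 1 oxygen, 1 chlorine; one six-membered aromatic ring with 1 hetero atom) in place of a group of 7 heavy atoms (6 carbon, 1 nitrogen; one six-membered aromatic ring with 1 hetero atom), on an aromatic carbon. For the measured compounds named here, no measured pair in this set isolates that change. The expected step from compound 2 to compound 3 is a number 8 percentage points higher from compound 2 to compound 3 (within the scatter), a modest rise, partly because compound 1 gives 74% while carrying the same entering group on a different core. Compound 3 is expected at 65%, range 45% to 82%.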

Compound 3, percent of the compound remaining: 72%
Beside the measured number, compound 3's estimate is 7 percentage points below it; the measured number falls inside the stated range.
By their numbers in this assay, from the lowest: compound 2; then compounds 3 and 1 (each within the scatter of the next).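

In this assay the read-out stands a number 15 percentage points higher from compound 2 to compound 3 (beyond the scatter) when the chlorine-bearing ring of compound 3 replaces 3-methylpyridin-4-yl on the aromatic carbon para to a large group. For the compounds shown here, this is the first reading of a change at this position alone, as compound 1 and compound 2 differ in more than one place. Nothing at hand accounts for the step. Going by these compounds, whether the step follows the ring or its chlorine stays open. Methoxy or nitrile in place of that chlorine, or an amine or a carboxylic acid at this position, would test that.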